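Dimethylamino in place of hydrogen: an expected read-out

The compounds below may be only part of what the source reports. "The series", "measured", "known", "first", "only" and "open" are said of these compounds alone.

Measured so far:
compound 1, `COc1cc(/C=C/C(=O)C2=C(/C=C/c3ccc(O)c(OC)c3)NC(=O)NC2c2ccc(C)cc2)ccc1O`: 23.9%
compound 2, `COc1cc(/C=C/C(=O)C2=C(/C=C/c3ccc(O)c(OC)c3)NC(=S)NC2c2ccccc2)ccc1O`: 22%

In a functional assay, with a stated time of 20 min, tested at 10 uM (on this read-out lower numbers stand for a weaker effect and higher numbers for a stronger effect at the one concentration tested), compound 2 gives 22%, and compound 1 gives 23.9%; the two numbers lie within the usual scatter of each other, so neither can be set apart from the other. Compound 3, `COc1cc(/C=C/C(=O)C2=C(/C=C/c3ccc(O)c(OC)c3)NC(=S)NC2c2ccc(N(C)C)cc2)ccc1O`, differs from compound 2 by dimethylamino in place of hydrogen on an aromatic carbon. For the measured compounds named here, no step between measured compounds bears on this change, so no direction can be read from the data. Compound 3 is therefore expected to show a step of a number 3 percentage points higher from compound 2 to compound 3 (within the scatter), none beyond the scatter. Compound 3 is estimated at 25%, with a range from 10% to 45%.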

Compound 3, a percentage reported as activity, at one concentration (the size of the read-out at that concentration, not a potency): 59%
Estimate against measurement, compound 3: 34 percentage points below; the whole stated range lies below it.
By their numbers in this assay, from the lowest: compounds 2 and 1 (each within the scatter of the next); then compound 3.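

In this assay, replacing phenyl with 4-(dimethylamino)phenyl gives a number 37 percentage points higher from compound 2 to compound 3 (beyond the scatter). This shows that the read-out responds to a change at this aromatic carbon, and that a single substituent there can move it well beyond the scatter. The compounds shown include no measurement that explains this step. They leave open whether a smaller amine, such as amino, or a methoxy group at the same place would give a similar step. They also leave open whether a carboxylic acid there would move the read-out the other way.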